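Swapping chloro for dimethylamino on a furan chalcone

This account rests on a few compounds, and the source may have more. Where it says the series, first, only, none or still open, it means among the compounds named here.

In a functional assay on MOLT-4 cells (Homo sapiens) for inhibition, read by MTT assay, with a stated time of 48 h (a higher number here means a weaker inhibitor, a lower number a stronger inhibitor), compound 2 `O=C(/C=C/c1ccc(Cl)cc1)c1ccco1` gives 23000 nM, the highest of the two numbers measured, with compound 1 `O=C(/C=C/c1ccc(Cl)cc1)c1ccc[nH]1` giving 22000 nM. The step of a 1.0-fold higher number from compound 1 to compound 2 (0.02 log units; within the scatter) changes only the ring on the carbonyl. Compound 3 `CN(C)c1ccc(/C=C/C(=O)c2ccco2)cc1` differs from compound 2 by dimethylamino in place of chloro on an aromatic carbon. Going by the values given here, that one measured step does not reach the position altered here, and no measured step bears on this change. With nothing to guide it, the step of a 1.3-fold lower number from compound 2 to compound 3 (0.11 log units; within the scatter) is expected to stay within the scatter, with a wide range. Compound 3 is estimated at 18000 nM, between 5000 nM and 60000 nM.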

Compound 3, half-maximal inhibitory concentration: 12000 nM
Beside the measured number, compound 3's estimate is 1.5-fold (0.18 log units) above it; measured number inside the range.
By their numbers in this assay, from the lowest: compounds 3, 1 and 2 (each within the scatter of the next).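

At this position on the six-membered aromatic ring, dimethylamino in place of chloro gives a 1.9-fold lower number from compound 2 to compound 3 (0.28 log units; within the scatter) in this assay. So a group of three heavy atoms that adds a hydrogen-bond acceptor can replace a single chlorine atom here without moving the number beyond the scatter, a first reading on this position that the ring swap between compounds 1 and 2 could not give. No supporting evidence bears on this result. Still open, on these data alone, is how a carboxylic acid or a longer chain at this position would read, and whether dimethylamino behaves alike on the core of compound 1.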